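The source may report more compounds than this note shows. Statements on the series, on what has been measured and on what is new or still open speak of the compounds shown alone.

Compound 1 `O=C(NCCCCc1ccccc1)n1cc(-c2ccccc2)oc1=O`: 0.667 h
Compound 2 `O=C(NCCCCc1ccccc1)n1cc(-c2ccc(F)cc2)oc1=O`: 1 h
Compound 3 `O=C(NCCCCc1ccccc1)n1cc(-c2ccncc2)oc1=O`: > 1 h (a limit)

In an ADME assay on microsomes from liver (Mus musculus) for metabolic stability, read by LC-MS, using NADPH, tested at 4.6 uM (on this read-out lower numbers stand for a shorter-lived compound and higher numbers for a longer-lived compound), compound 2 gives 1 h. That places it within the scatter of compound 1, with a 1.5-fold higher number from compound 1 to compound 2 (0.18 log units; within the scatter). Compound 3 gives > 1 h, which is a limit of the assay and not a number. Its steps are an at least 1.4-fold higher number from compound 1 to compound 3 (0.17 log units; that floor lies within the scatter) and a number no lower from compound 2 to compound 3 (the limit leaves the size open).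

Compound 4 `CN1CCC(c2cc(-c3cn(C(=O)NCCCCc4ccccc4)c(=O)o3)ccc2F)CC1` builds on compound 2 with one change, 1-methylpiperidin-4-yl in place of hydrogen on an aromatic carbon, ortho to a fluoro group. The measured steps offer only weak guidance, since each swaps a single atom or ring on the same aromatic position and none adds a group like this one. None of them shows a change beyond the scatter, so no clear shift in half-life can be predicted, and the uncertainty is wide. The expected step is a 1.3-fold lower number from compound 2 to compound 4 (0.10 log units; within the scatter), which stays within the scatter. For compound 4 the estimated half-life is 0.8 h, with an expected range of 0.3 h to 2 h.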

Compound 4, half-life: > 1 h
Compound 4: no number, only a limit; the forecaster's own chance of this, stated with the estimate: 20%; middle value at least 1.2-fold (0.09 log units) from the limit.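

In this assay compound 4 gives > 1 h, which is a limit of the assay and not a number. Within the data shown here, the new finding is that a whole 1-methylpiperidin-4-yl group can sit on this aromatic carbon, ortho to a fluoro group, with a number no lower from compound 2 to compound 4 (the limit leaves the size open), whereas the earlier compounds changed only one atom or swapped one ring for another. How far the half-life moves cannot be read, because the read-out stops at a limit: the limit of > 1 h in this assay, at which 2 of the 4 values shown sit.

The compounds shown leave open whether the nitrogen of the new group matters, which a cyclohexyl group on the same carbon would help to test. They also leave open whether a much smaller group, such as a methyl group, would give a similar result there.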